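The source may hold more compounds than are shown below. What is called first, only, known or untested is meant among the compounds shown, and "the series" means these compounds.

Measured in an ADME assay on Vero cells (Chlorocebus sabaeus) for cytotoxicity, read by MTT assay, with a stated time of 72 h; a lower number here means a stronger inhibitor, a higher number a weaker inhibitor:
Compound 1 `CS(=O)(=O)c1ccc(-c2ccnc(Nc3cccc(C(N)=O)c3)n2)cc1`: 37900 nM
Compound 2 `CS(=O)(=O)c1ccc(-c2ccnc(Nc3cccc(S(N)(=O)=O)c3)n2)cc1`: > 100000 nM, a limit of the assay

Within the data shown here, compound 1 gives the only exact number in this assay, 37900 nM, so there is no series of numbers to rank it in. Compound 3 `CC(=O)Nc1ccc(-c2ccnc(Nc3cccc(C(N)=O)c3)n2)cc1` keeps the core of compound 1 and its carbamoyl, but carries acetamido in place of methylsulfonyl on an aromatic carbon, para to a large group (acetamido in place of methylsulfonyl on an aromatic carbon). Among the measured compounds shown here, the one measured step, an at least 2.6-fold higher number from compound 1 to compound 2 (0.42 log units; beyond the scatter), is beyond the scatter, but it changes the carbamoyl and leaves the methylsulfonyl untouched. Compound 2 stands at the limit of > 100000 nM in this assay, at which 1 of the 2 values shown sits, so the size of that step is itself bounded by a limit. For the measured compounds named here, no measured step therefore bears directly on this exchange, and no shift beyond the scatter is expected in this assay. The expected change is a 1.1-fold higher number from compound 1 to compound 3 (0.02 log units; within the scatter). Compound 3 is estimated at 40000 nM, with an expected range from 12000 nM to 100000 nM.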

Compound 3, half-maximal inhibitory concentration: > 100000 nM
Compound 3: only a limit was reported; the forecaster's own chance of this, stated with the estimate: 15%; middle value at least 2.5-fold (0.39 log units) away from the limit.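

In this assay, the place para to a large group also bears on the read-out: acetamido in place of methylsulfonyl gives an at least 2.6-fold higher number from compound 1 to compound 3 (0.42 log units; beyond the scatter). Until now only the exchange of the carbamoyl had been seen to move the number, whereas both changes made to compound 1 now lie beyond the scatter. The size of this new step is only bounded, as compound 3 gives a limit of the assay and not a number: the limit of > 100000 nM in this assay, at which 2 of the 3 values shown sit.

Among these compounds, compound 1 remains the only exact number, at 37900 nM, so how far either exchange truly reaches cannot be read. As far as these compounds go, whether an amine or a carboxylic acid at this place, or a longer chain in place of acetamido, would also raise the number or leave it close to that of compound 1 stays open.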